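Two Thiocarbamoyl Arms on a Piperazine Core

The source may report more compounds than this note shows. Statements on the series, on what has been measured and on what is new or still open speak of the compounds shown alone.

Compounds measured so far, with their values in an ADME assay on HeLa cells (Homo sapiens) for cytotoxicity, read by MTT assay, with a stated time of 24 h; a lower number here means a stronger inhibitor, a higher number a weaker inhibitor:
compound 1 `CCCCN1CCN(C(=S)SC(=S)N(C)C)CC1` gives 4100000 nM;
compound 2 `CN(C)C(=S)SC(=S)N1CCN(c2ccccc2)CC1` gives 1610000 nM;
compound 3 `CN(C)C(=S)SC(=S)N1CCN(C(=O)c2ccco2)CC1` gives 2380000 nM.

Compound 3 stands second highest of the three numbers; its nearest neighbour is compound 2, and the gap from compound 2 to compound 3 is a 1.5-fold higher number from compound 2 to compound 3 (0.17 log units; within the scatter), while the gap from compound 1 to compound 3 is a 1.7-fold lower number from compound 1 to compound 3 (0.24 log units; within the scatter). Among the compounds with values here, only the step from compound 1 to compound 2 reaches beyond the scatter, a 2.5-fold lower number from compound 1 to compound 2 (0.41 log units; beyond the scatter), and it is modest.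

Compound 4 `CCCCSC(=S)N1CCN(C(=S)SC(=S)N(C)C)CC1` differs from compound 3 in one place: a group of 7 heavy atoms (5 carbon, 2 sulfur; no ring) in place of a group of 7 heavy atoms (5 carbon, 2 oxygen; one five-membered aromatic ring with 1 hetero atom), on an amine nitrogen in a ring. Within the data shown here, no measured step exchanges a group of this kind on that ring nitrogen, so the three measured steps bear on it only by showing how narrow the spread is across butyl, phenyl and (furan-2-yl)carbonyl. Since all three numbers sit within a small span, compound 4 is expected to fall close to compound 3, with a step of a 1.2-fold lower number from compound 3 to compound 4 (0.08 log units; within the scatter) that may well stay within the scatter. The estimate for compound 4 is 2000000 nM, with a range from 800000 nM to 5000000 nM.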

Compound 4, half-maximal inhibitory concentration: > 5000000 nM
Compound 4: no number, only a limit; the forecaster's own chance of this, stated with the estimate: 10%; at least 2.5-fold (0.39 log units) between middle value and limit.
By their numbers in this assay, from the lowest: compounds 2, 3 and 1 (each within the scatter of the next, the first and the last beyond it). At a limit, above all of these: compound 4.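

Compound 4 gives no number in this assay, only a limit: the limit of > 5000000 nM in this assay, at which 1 of the 4 values shown sits. The earlier groups on this amine nitrogen in a ring stayed in a narrow span, but the group of 7 heavy atoms with 5 carbon and 2 sulfur breaks it, with an at least 2.1-fold higher number from compound 3 to compound 4 (0.32 log units; beyond the scatter) and an at least 3.1-fold higher number from compound 2 to compound 4 (0.49 log units; beyond the scatter), so that span does not hold for every group here. In place of butyl the same group gives an at least 1.2-fold higher number from compound 1 to compound 4 (0.08 log units; that floor lies within the scatter), and this floor alone does not set it apart.

From the compounds shown here alone, how far the true value of compound 4 lies past its limit stays open. So does which part of the entering group matters, and whether a shorter chain such as methyl, or a terminal amine or carboxylic acid, would bring the number back within the measured span.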